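The compounds below may be only part of what the source reports. "The series", "measured", "known", "first", "only" and "open" are said of these compounds alone.

Three compounds have been measured in a functional assay on MCF7 cells (Homo sapiens) for antiproliferative activity, read by CCK-8 assay, with a stated time of 72 h (a higher number here means a weaker inhibitor of growth, a lower number a stronger inhibitor of growth), so far:

- compound 1 `CCC1C(=O)N(C)c2cnc(Nc3ccc(S(=O)(=O)NCC(C)C)cc3)nc2N1c1ccn(C)n1` gives 8350 nM
- compound 2 `CCCNS(=O)(=O)c1ccc(Nc2ncc3c(n2)N(c2ccn(C)n2)C(CC)C(=O)N3C)cc1` gives 3000 nM
- compound 3 `CCCNC(=O)c1ccc2c(ccn2-c2ncc3c(n2)N(c2ccn(C)n2)C(CC)C(=O)N3C)c1` gives 6420 nM

Compound 3 sits within the usual scatter of compound 1, so those two cannot be told apart. Its number is higher than that of compound 2, and that gap lies beyond the scatter, which means compound 3 inhibits growth less strongly.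

The next molecule, compound 4 `CCC1C(=O)N(C)c2cnc(-n3ccc4cc(C(N)=O)ccc43)nc2N1c1ccn(C)n1`, differs from compound 3 in one place: hydrogen in place of propyl on an amide-type nitrogen In words, this is hydrogen in place of propyl on an amide-type nitrogen, so propylcarbamoyl becomes carbamoyl.

Going by the values given here, only one measured step offers a comparison. Among the compounds with values here, it also trims an alkyl chain, with hydrogen in place of methyl on a saturated chain carbon, and it gives a 2.8-fold lower number from compound 1 to compound 2 (0.44 log units; beyond the scatter) That step is modest and sits on a different group, so it is a weak guide, and nothing measured so far shows what removing a whole propyl from an amide does. A modest move to a lower number in this assay is therefore expected, of similar size to that one precedent. The estimated change is a 2.1-fold lower number from compound 3 to compound 4 (0.33 log units; beyond the scatter) and it could easily turn out to be none at all. For compound 4 the expected value is 3000 nM with an estimated range from 900 nM to 10000 nM as a deliberately wide allowance.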

Compound 4, concentration for 50% growth inhibition: "not active" (no number reported)
Compound 4: no number reported; the estimate stays without a comparison.
By their numbers in this assay, from the lowest: compound 2; then compounds 3 and 1 (each within the scatter of the next).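

Going by these compounds alone, compound 4 is reported as "not active" in this assay with no number, so no step from compound 3 to compound 4 can be read. The compounds shown leave open how much replacing propyl with hydrogen on the amide-type nitrogen changes growth inhibition. No measured evidence here explains this result.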